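The source may hold more compounds than are shown below. What is called first, only, known or untested is meant among the compounds shown, and "the series" means these compounds.

Of the compounds shown here, three built on one shared core have been tested in a functional assay on CHO cells for agonist activity at G-protein coupled receptor 52 (Homo sapiens), read by AlphaScreen and cAMP accumulation, with a stated time of 30 min; a lower number here means that less compound is needed, a higher number that more compound is needed for the effect. Compound 1 `O=C(NCCO)c1cccc(-c2cccc3cc(Cc4cccc(C(F)(F)F)c4)sc23)c1` gives 37.2 nM. Compound 2 `NC(=O)CNC(=O)c1cccc(-c2cccc3cc(Cc4cccc(C(F)(F)F)c4)sc23)c1` gives 55 nM. Compound 3 `COCCNC(=O)c1cccc(-c2cccc3cc(Cc4cccc(C(F)(F)F)c4)sc23)c1` gives 42.7 nM. On these numbers compound 3 stands second highest of the three, with compound 1 nearest and compound 2 furthest, though every gap between them lies within the scatter. The measured steps all concern the amide tail of the core: a 1.5-fold higher number from compound 1 to compound 2 (0.17 log units; within the scatter), a 1.1-fold higher number from compound 1 to compound 3 (0.06 log units; within the scatter), and a 1.3-fold lower number from compound 2 to compound 3 (0.11 log units; within the scatter). None of them reaches beyond the scatter.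

Compound 4 `COCCNC(=O)c1cccc(-c2cccc3cc(Cc4cc(F)cc(Cl)c4)sc23)c1` has not yet been measured. It differs from compound 3 in another part of the molecule: 3-chloro-5-fluorophenyl in place of 3-(trifluoromethyl)phenyl on a saturated chain carbon bound to an aromatic carbon. Going by the values given here, no measured step touches this benzyl group, so the three steps carry no direct information about it; they show only that changes elsewhere on the core moved the numbers little. Without a precedent, the expected step in this assay is a 1.2-fold higher number from compound 3 to compound 4 (0.07 log units; within the scatter), that is, no shift beyond the scatter, with a wide range reflecting the lack of evidence. Compound 4 is therefore estimated at 50 nM in this assay, within 15 nM to 160 nM.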

Compound 4, half-maximal effective concentration: 29.5 nM
Beside the measured number, compound 4's estimate is 1.7-fold (0.23 log units) above it; the range from low to high includes it.
By their numbers in this assay, from the lowest: compounds 4, 1, 3 and 2 (each within the scatter of the next).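

Going by these compounds alone, the earlier steps all concerned the amide tail, and this is the first look at the group on the other side of the shared core. In this assay, putting 3-chloro-5-fluorophenyl in place of 3-(trifluoromethyl)phenyl on a saturated chain carbon bound to an aromatic carbon gives a 1.4-fold lower number from compound 3 to compound 4 (0.16 log units; within the scatter) and so leaves the two compounds unseparated, even though the entering group has fewer heavy atoms than the leaving group. Thus this position accepts a ring bearing chlorine and fluorine in place of one bearing trifluoromethyl with no shift beyond the scatter, but nothing available explains why the two read alike.

One exchange on a single tail cannot say whether the same swap would read alike on the tails of compound 1 and compound 2. Also open, on these data alone, is how this assay would respond at this position to a phenyl ring carrying a nitrile or a methoxy group, to a pyridine ring, or to an unsubstituted phenyl ring, any of which would show how much the ring's substituents matter at all.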